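The compounds below may be only part of what the source reports. "The series", "measured", "known", "first", "only" and "open" are said of these compounds alone.

Within the data shown here, compound 2 `O=c1cc(Cn2cc(CCCCl)nn2)c2ccc(O)cc2o1` is the one compound here with a plain number: in a functional assay on HeLa cells (Homo sapiens) for inhibition, read by MTT assay, with a stated time of 72 h (on this read-out higher numbers stand for weaker inhibition and lower numbers for stronger inhibition), compound 2 gives 49600 nM. Compound 1 `O=c1cc(Cn2cc(C3CC3)nn2)c2ccc(O)cc2o1` returns a limit in this assay, > 100000 nM, and not a number. Between the two lies a single step, an at least 2.0-fold lower number from compound 1 to compound 2 (0.30 log units; that floor lies within the scatter), whose size is known only as a floor, since the limit of > 100000 nM in this assay, at which 1 of the 2 values shown sits, fixes one side of it. Compound 3 `O=c1cc(Cn2cc(CCO)nn2)c2ccc(O)cc2o1` differs from compound 2 by hydroxy in place of chloromethyl on a saturated chain carbon, two bonds along the chain from an aromatic carbon. Among the measured compounds shown here, the one measured step bears on this change only loosely: it concerns the same chain, yet its floor sits within the scatter and sets no firm direction, and no measured step speaks to a hydroxy group in that place. In this assay the expected step for compound 3 is therefore small, a 1.2-fold higher number from compound 2 to compound 3 (0.08 log units; within the scatter), not beyond the scatter in either direction. Compound 3 is estimated at 60000 nM, with a range from 20000 nM to 150000 nM.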

Compound 3, half-maximal inhibitory concentration: > 100000 nM
Compound 3 gave a limit, no number; the forecaster's own chance of this, stated with the estimate: 30%; middle value at least 1.6-fold (0.22 log units) from the limit.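

In this assay, hydroxy in place of chloromethyl on a saturated chain carbon, two bonds along the chain from an aromatic carbon, gives an at least 2.0-fold higher number from compound 2 to compound 3 (0.30 log units; that floor lies within the scatter) and so sets no firm direction for this change. Among these compounds, compound 3 returns a limit and not a number, which leaves the 3-chloropropyl chain of compound 2 as the only group here that yields a plain number. The step between compound 1 and compound 3 cannot be read, and the new step is known only as a floor because compound 3 sits at a limit: the limit of > 100000 nM in this assay, at which 2 of the 3 values shown sit.

On these data alone, how far compound 3 lies past that limit stays open. Also open, as far as these compounds go, is whether an amine or a carboxylic acid in that place, or a longer chain, would give a plain number.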